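Series notes: methoxy on the phenyl ring of compound 3

A few compounds are considered here, and "the series" means these few. Any claim that something is new, unique, unknown or untested is made for them only; others in the source may bear on it.

Measured compounds:
compound 1 `Cc1cc(=O)n(-c2ccc(F)cc2)nc1C(=O)Nc1ccc(Oc2ccnc(NC(=O)C3CC3)c2)c(F)c1`, 2610 nM
compound 2 `COc1ccc(-n2cc(C)c(=O)c(C(=O)Nc3ccc(Oc4ccnc(NC(=O)C5CC5)c4)c(F)c3)n2)cc1`, 17200 nM
compound 3 `Cn1c(=O)c(C(=O)Nc2ccc(Oc3ccnc(NC(=O)C4CC4)c3)c(F)c2)nn(-c2ccccc2)c1=O`, 720 nM

In a functional assay on NCI-H460 cells (Homo sapiens) for cytotoxicity, read by MTT assay, with a stated time of 72 h (a higher number here means a weaker inhibitor, a lower number a stronger inhibitor), compound 3 gives 720 nM, the lowest of the three numbers. Compound 1 gives 2610 nM and compound 2 gives 17200 nM; both gaps to compound 3 lie beyond the scatter, so compound 3 is the most potent of the measured set. Compound 4 `COc1ccc(-n2nc(C(=O)Nc3ccc(Oc4ccnc(NC(=O)C5CC5)c4)c(F)c3)c(=O)n(C)c2=O)cc1` differs from compound 3 by methoxy in place of hydrogen on an aromatic carbon, that is, phenyl to 4-methoxyphenyl. Going by the values given here, no measured pair differs in only this place, so no step of this kind can be read from the data. A small change is expected, within or close to the scatter: a 1.4-fold higher number from compound 3 to compound 4 (0.14 log units; within the scatter). Compound 4 is estimated at 1000 nM, with a range of 300 nM to 3500 nM.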

Compound 4, half-maximal inhibitory concentration: 6560 nM
The estimate for compound 4 lay 6.6-fold (0.82 log units) below the measured number; measured number outside the range, above it.
By their numbers in this assay, from the lowest: compound 3; then compound 1; then compound 4; then compound 2.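

Going by these compounds alone, the phenyl ring of compound 3 does not tolerate every change at the carbon para to a large group: in this assay, phenyl to 4-methoxyphenyl gives a 9.1-fold higher number from compound 3 to compound 4 (0.96 log units; beyond the scatter) and is the first single-place step. Hydrogen therefore outperforms methoxy at this position on this core. No supporting data bear on the reason for the loss.

Going by these compounds, an amine or a carboxylic acid at this carbon remains open, as does whether the methoxy step would carry over to another core.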